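Urea to acetamide on the sulfonamide chain: permeability outlook

The source may hold more compounds than are shown below. What is called first, only, known or untested is meant among the compounds shown, and "the series" means these compounds.

Measured so far:
Compound 1, `CC(C)S(=O)(=O)NC(=O)c1ccc(Nc2nc(NC3(c4ccc(Cl)cc4)CC3)nc(OCC(F)(F)F)n2)cc1`, gives 31 nm/s.
Compound 2, `CCS(=O)(=O)NC(=O)c1ccc(Nc2nc(NC3(c4ccc(Cl)cc4)CC3)nc(OCC(F)(F)F)n2)cc1`, gives 28 nm/s.
Compound 3, `CNC(=O)NCCS(=O)(=O)NC(=O)c1ccc(Nc2nc(NC3(c4ccc(Cl)cc4)CC3)nc(OCC(F)(F)F)n2)cc1`, gives 40 nm/s.

These three share one core and differ only in the group on the sulfonyl sulfur. In a physicochemical assay for permeability, using PAMPA, at pH 7.4 (on this read-out higher numbers stand for higher permeability and lower numbers for lower permeability), compound 3 sits at the high end of the three numbers, but its steps to both neighbours are within the scatter: a 1.3-fold higher number from compound 1 to compound 3 (0.11 log units; within the scatter) and a 1.4-fold higher number from compound 2 to compound 3 (0.15 log units; within the scatter). The step of a 1.1-fold lower number from compound 1 to compound 2 (0.04 log units; within the scatter) is likewise within the scatter. For the measured compounds named here, on these numbers no compound can be called more or less permeable than another.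

Compound 4, `CC(=O)NCCS(=O)(=O)NC(=O)c1ccc(Nc2nc(NC3(c4ccc(Cl)cc4)CC3)nc(OCC(F)(F)F)n2)cc1`, has not yet been measured in this assay. It differs from compound 3 in one place: methyl in place of methylamino on a carbonyl carbon. The measured steps that bear on this are those that built up the sulfonyl substituent, from compound 1 and compound 2 to compound 3, and both were within the scatter even though they changed more of the chain than this step does. Compound 4 is therefore expected to show a step of a 1.1-fold higher number from compound 3 to compound 4 (0.04 log units; within the scatter), that is, no change beyond the scatter. Compound 4 is estimated at 44 nm/s, with a range from 24 nm/s to 80 nm/s.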

Compound 4, apparent permeability: 7 nm/s
Compound 4: the middle estimate sits 6.3-fold (0.80 log units) above what was measured; the whole stated range lies above it.
By their numbers in this assay, from the lowest: compound 4; then compounds 2, 1 and 3 (each within the scatter of the next).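

In this assay, for the compounds shown here, the end of this sulfonyl chain proves sensitive to a small edit: methyl in place of methylamino on the carbonyl carbon gives a 5.7-fold lower number from compound 3 to compound 4 (0.76 log units; beyond the scatter), the first step beyond the scatter. Compound 4 also stands apart from the compounds with short chains, with a 4.0-fold lower number from compound 2 to compound 4 (0.60 log units; beyond the scatter) and a 4.4-fold lower number from compound 1 to compound 4 (0.65 log units; beyond the scatter), whereas compound 3 stayed within the scatter of both, so adding a chain of this kind does not by itself set the outcome. Nothing shown here explains the difference.

The compounds shown leave open whether the low number belongs to acetamido alone or extends to related ends on this chain. An ethyl or a methoxy in place of the methyl on the carbonyl carbon, or a dimethylamino in place of the methylamino, would help separate these readings.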